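A few compounds are considered here, and "the series" means these few. Any claim that something is new, unique, unknown or untested is made for them only; others in the source may bear on it.

Compound 1, `COc1ccc(N2C(=O)COc3ccc(-c4cnc5ccccc5c4)cc32)cc1`: > 40000 nM in a functional assay on HepG2 cells (Homo sapiens) for antiproliferative activity, read by MTT assay, with a stated time of 72 h (a higher number here means a weaker inhibitor, a lower number a stronger inhibitor), a limit of the assay.
Compound 2, `O=C1COc2ccc(-c3cccc(NS(=O)(=O)c4ccc(F)cc4)c3)cc2N1c1ccccc1`: 30300 nM in this assay.
Compound 3, `Cc1ccc(N2C(=O)COc3ccc(-c4cnc5ccccc5c4)cc32)cc1`: > 40000 nM in this assay, a limit of the assay.

Compound 3 stands at the limit of > 40000 nM in this assay, at which 2 of the 3 values shown sit, so only a limit and no number is known for it. Compound 4, `O=C1COc2ccc(-c3cnc4ccccc4c3)cc2N1c1ccccc1`, differs from compound 3 by hydrogen in place of methyl on an aromatic carbon. Within the data shown here, the single measured step, a step that the two limits leave unreadable from compound 1 to compound 3, is of unreadable size, and so no measured step bears on this change. Compound 2 differs from compound 4 in more than one place. Among the measured compounds shown here, as the one compound with a number rather than a limit, compound 2 gives 30300 nM. Compound 4 is therefore expected to remain weak, estimated at 40000 nM with a range of 15000 nM to 100000 nM. The step of a number no higher from compound 3 to compound 4 (the limit leaves the size open) is expected to lie within the scatter, though the assay may again report only a limit.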

Compound 4, half-maximal inhibitory concentration: > 40000 nM
Compound 4 ended at the assay's limit (the forecaster's own chance of this, stated with the estimate: 60%); the middle value sits exactly at the limit.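

Among these compounds, compound 1, compound 3 and compound 4 all stand only at a limit in this assay, and no step among them can be read. The compounds shown leave open whether hydrogen, methyl or methoxy on that aromatic carbon makes any difference.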